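A few compounds are considered here, and "the series" means these few. Any claim that something is new, unique, unknown or untested is made for them only; others in the source may bear on it.

Measured so far:
- compound 1, `Oc1ccc(CNc2cc(C(F)(F)F)cc3[nH]ncc23)c(Cl)c1`, an assay for inhibition of Indoleamine 2,3-dioxygenase 1 (Homo sapiens), with stated times of 10 min and 60 min (on this read-out higher numbers stand for weaker inhibition and lower numbers for stronger inhibition), 6020 nM
- compound 2, `O=[N+]([O-])c1cc(Cl)ccc1CNc1cc(C(F)(F)F)cc2[nH]ncc12`, this assay 18000 nM

Compound 2 carries the highest number of the two measured in this assay; the nearest is compound 1, whose number is lower by a gap that lies beyond the usual scatter. Within the data shown here, no step between compounds that differ in one place has been computed for this pair, so the two values stand side by side without further reading.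

Compound 3, `O=[N+]([O-])c1ccccc1CNc1cc(C(F)(F)F)cc2[nH]ncc12`, has not been measured. It differs from compound 2 by hydrogen in place of chloro on an aromatic carbon. Without a comparable step among the measured compounds, the expectation rests on the change itself: a single chlorine removed with nothing added. The expected step in this assay is small, if anything toward a higher number, and may well fall within the scatter. The estimated step from compound 2 to compound 3 is a 1.4-fold higher number from compound 2 to compound 3 (0.14 log units; within the scatter). Compound 3 is expected to give 25000 nM in this assay, with a range from 9000 nM to 70000 nM.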

Compound 3, half-maximal inhibitory concentration: 14000 nM
Estimate against measurement, compound 3: 1.8-fold (0.25 log units) above; measured number inside the range.
By their numbers in this assay, from the lowest: compound 1; then compounds 3 and 2 (each within the scatter of the next).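

In this assay, hydrogen in place of chloro on this aromatic carbon, meta to a nitro group and para to a large group, gives a 1.3-fold lower number from compound 2 to compound 3 (0.11 log units; within the scatter). Among these compounds, this is the first pair that differs in one place, and it does not tell chloro and hydrogen apart at this position with the nitro group present. Nothing measured alongside these numbers bears on this result.

Compound 1 differs from compound 2 and compound 3 in more than one place, so steps to it cannot be read, and no single group can be linked to its value. Also open, as far as these compounds go, is how other groups on this aromatic carbon, such as an amine, a methoxy group or a carboxylic acid, would read.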